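This account rests on a few compounds, and the source may have more. Where it says the series, first, only, none or still open, it means among the compounds named here.

Working notes on the series. In an assay on isolated protein for displacement of a labelled ligand from metabotropic glutamate receptor 5 (Homo sapiens), with a stated time of 60 min, tested at 1 uM (a lower number here means less inhibition, a higher number more inhibition at the concentration tested (going by the name of the read-out)), compound 1 `CC1CCN(c2c(S(=O)(=O)c3ccc(C#N)cc3)cnc3cc(Cl)ccc23)CC1` gives 70% and compound 2 `CC1CCN(c2c(S(=O)(=O)c3cccc(C#N)c3)cnc3cc(Cl)ccc23)CC1` gives 94%; compound 2 stands highest of the two, the only shown step being a number 24 percentage points higher from compound 1 to compound 2 (beyond the scatter). Compound 3 `Cc1ccc(S(=O)(=O)c2cnc3cc(Cl)ccc3c2N2CCC(C)CC2)cc1Cl` is not yet measured; it differs from compound 2 by 3-chloro-4-methylphenyl in place of 3-cyanophenyl on a sulfonyl sulfur. No measured step bears on this exchange, since the one shown moves a nitrile on the same ring rather than replacing it, so the direction of the step in this assay is open. A moderate loss is taken as the working expectation, a number 14 percentage points lower from compound 2 to compound 3 (beyond the scatter), giving for compound 3 an estimate of 80% with a range of 50% to 98%.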

Compound 3, a percentage reported as inhibition, at one concentration (the size of the read-out at that concentration, not a potency): 89%
Compound 3: middle estimate off by 9 percentage points, on the low side, and the stated range covers the measured number.
By their numbers in this assay, from the lowest: compound 1; then compounds 3 and 2 (each within the scatter of the next).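

In this assay, a nitrile on the aryl group at the sulfonyl sulfur proves dispensable: the exchange gives a number 5 percentage points lower from compound 2 to compound 3 (within the scatter) and leaves 3-chloro-4-methylphenyl level with 3-cyanophenyl. Against 4-cyanophenyl the same group gives a number 19 percentage points higher from compound 1 to compound 3 (beyond the scatter) in a clear gain, so the nitrile-free ring matches only the better of the two nitrile compounds. No measurement on hand explains this outcome.

Open, as far as these compounds go, is how a 3-chlorophenyl, a 4-methylphenyl or a saturated cyclohexyl group on the sulfonyl sulfur would compare. Also open, from the compounds shown here alone, is whether compound 2 and compound 3 differ in potency, which a percentage at one concentration cannot tell.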